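From isobutoxy to allyloxy in a narrow series

The source may hold more compounds than are shown below. What is called first, only, known or untested is meant among the compounds shown, and "the series" means these compounds.

Measured in a functional assay on J774.A1 cells (Mus musculus) for inhibition, read by Griess assay, with stated times of 1 h and 24 h; a higher number here means a weaker inhibitor, a lower number a stronger inhibitor:
- compound 1 `O=C1CC(c2ccccc2OCc2ccc(F)cc2)Oc2ccccc21`: 25500 nM
- compound 2 `CC(C)CCOc1ccccc1C1CC(=O)c2ccccc2O1`: 42600 nM
- compound 3 `CC(C)COc1ccccc1C1CC(=O)c2ccccc2O1`: 33200 nM

In this assay compound 3 gives 33200 nM, which lies within the scatter of both other measured compounds. The next compound to be tested is compound 4 `C=CCOc1ccccc1C1CC(=O)c2ccccc2O1`. Its structure differs from that of compound 3 as follows: vinyl in place of isopropyl on a saturated chain carbon bound to an oxygen on an aromatic ring. In words, this is vinyl in place of isopropyl on a saturated chain carbon bound to an oxygen on an aromatic ring, which also reads as isobutoxy to allyloxy.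

Going by the values given here, no measured step introduces vinyl, so the evidence is indirect. The closest guide is a 1.3-fold lower number from compound 2 to compound 3 (0.11 log units; within the scatter). The exchanges with the 4-fluorophenyl group are also small: a 1.7-fold higher number from compound 1 to compound 2 (0.22 log units; within the scatter) and a 1.3-fold higher number from compound 1 to compound 3 (0.11 log units; within the scatter). All three steps stay within the scatter, so no step beyond the scatter is expected here, in either direction. The estimated step is a 1.1-fold higher number from compound 3 to compound 4 (0.02 log units; within the scatter). For compound 4 the expected value is 35000 nM, with an estimated range from 18000 nM to 70000 nM.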

Compound 4, half-maximal inhibitory concentration: 38600 nM
For compound 4 the middle estimate is 1.1-fold (0.04 log units) below the measured one, and the stated range covers the measured number.
By their numbers in this assay, from the lowest: compounds 1, 3, 4 and 2 (each within the scatter of the next).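

In this assay, a double bond outside aromatic rings now stands on a saturated chain carbon bound to an oxygen on an aromatic ring, and all three new steps stay within the scatter (a 1.2-fold higher number from compound 3 to compound 4 (0.07 log units; within the scatter)), (a 1.1-fold lower number from compound 2 to compound 4 (0.04 log units; within the scatter)), (a 1.5-fold higher number from compound 1 to compound 4 (0.18 log units; within the scatter)). Vinyl therefore joins isopropyl, isobutyl and 4-fluorophenyl as a group this assay does not separate from the others at this place, so the earlier lack of separation now extends to an unsaturated group. Nothing available explains why these numbers lie so close together.

The compounds shown leave open whether any group at this place can produce a step beyond the scatter. An amine, a carboxylic acid or a longer chain there would put that question to the test.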